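Acetylating the phenol of a nitrobenzothiazole salicylamide

The source may report more compounds than this note shows. Statements on the series, on what has been measured and on what is new or still open speak of the compounds shown alone.

Measured compounds:
compound 1 `O=C(Nc1nc2ccc([N+](=O)[O-])cc2s1)c1ccccc1O`: 607000 nM
compound 2 `O=C(Nc1ncc([N+](=O)[O-])s1)c1ccccc1O`: 388000 nM

Of the compounds shown here, two have been tested in an ADME assay on Vero cells (Chlorocebus sabaeus) for cytotoxicity, read by MTT assay, with a stated time of 72 h; a higher number here means that more compound is tolerated, a lower number that less compound is tolerated. Compound 1 gives 607000 nM, and compound 2, which carries a smaller core, gives 388000 nM. These two numbers sit within the usual scatter of repeated measurements of each other, so on the data shown compound 1 stands at the same level of tolerance as compound 2, with no ranking possible between them.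

Compound 3 `CC(=O)Oc1ccccc1C(=O)Nc1nc2ccc([N+](=O)[O-])cc2s1` is not yet measured. It differs from compound 1 by acetyl in place of hydrogen on an oxygen on an aromatic ring. Among the measured compounds shown here, since no measured pair with this kind of change exists here, the expected step is drawn only from how little the two measured values differ: the step is expected to lie within the scatter and to point in no clear direction. In this assay the expected step is a 1.2-fold lower number from compound 1 to compound 3 (0.08 log units; within the scatter). Compound 3 is therefore estimated at 500000 nM, within a range from 250000 nM to 1000000 nM.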

Compound 3, half-maximal cytotoxic concentration: 683000 nM
The estimate for compound 3 lay 1.4-fold (0.14 log units) below the measured number; measured number inside the range.
By their numbers in this assay, from the lowest: compounds 2, 1 and 3 (each within the scatter of the next).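

Among the compounds shown here, compound 1 and compound 3 differ in one place only, so this pair gives the first direct reading of a change on the oxygen on the aromatic ring: in this assay, going from hydroxy to acetoxy gives a 1.1-fold higher number from compound 1 to compound 3 (0.05 log units; within the scatter). That step lies within the usual scatter, so the two compounds stand at the same level of tolerance, and this one change to the hydroxy group leaves no readable mark on the number. Nothing measured here offers an explanation for this result.

Going by these compounds, whether a methyl ether or a longer acyl chain such as benzoyl on the same oxygen would also stay within the scatter remains open. So does whether acetyl in place of hydrogen on the oxygen of compound 2 would give a similar step.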